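This account rests on a few compounds, and the source may have more. Where it says the series, first, only, none or still open, it means among the compounds named here.

Three esters built on one shared core have been tested in an assay on NIH3T3 cells with Urotensin-2 receptor (Homo sapiens) as the target; a lower number here means a smaller maximal response, a higher number a larger maximal response. Compound 1 `CN(C)CCC(OC(=O)c1cn(C)c2ccccc12)c1ccc(Cl)cc1` gives 104%, compound 2 `COc1ccc(C(=O)OC(CCN(C)C)c2ccc(Cl)cc2)cc1` gives 84%, and compound 3 `CN(C)CCC(OC(=O)c1ccc2ccccc2c1)c1ccc(Cl)cc1` gives 49%. Compound 2 stands second highest of the three: its nearest neighbour, compound 1, lies higher by a margin beyond the scatter, while compound 3 lies further below it, again beyond the scatter. Compound 4 `Cc1cc(Br)ccc1C(=O)OC(CCN(C)C)c1ccc(Cl)cc1` differs from compound 2 in one place: 4-bromo-2-methylphenyl in place of 4-methoxyphenyl on a carbonyl carbon. Within the data shown here, no measured pair differs in exactly this way, so no comparable step exists. Both groups carry one six-membered aromatic ring of carbon only, and for compound 4 the expected step is a number 9 percentage points lower from compound 2 to compound 4 (within the scatter), not clearly beyond the scatter. Compound 4 is therefore expected to reach about 75%, between 45% and 105%.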

Compound 4, largest response reached (reported as efficacy), in percent of the reference or control that the assay uses: 95%
Estimate against measurement, compound 4: 20 percentage points below; low and high end bracket the measured number.
By their numbers in this assay, from the lowest: compound 3; then compound 2; then compounds 4 and 1 (each within the scatter of the next).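

In this assay, 4-bromo-2-methylphenyl in place of 4-methoxyphenyl on a carbonyl carbon gives a number 11 percentage points higher from compound 2 to compound 4 (beyond the scatter), a modest step. The maximal response at this position therefore shifts even though both groups carry one six-membered aromatic ring of carbon only and have the same heavy-atom count. No measured evidence explains this shift.

The change swaps several features at once, so the compounds shown cannot separate the contribution of the bromine from that of the methyl or the lost methoxy. As far as these compounds go, how a phenyl group carrying an amine or a carboxylic acid would behave here also remains open.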